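The compounds below may be only part of what the source reports. "The series", "measured", "known", "first", "only" and "open" are said of these compounds alone.

In a functional assay on MCF7 cells (Homo sapiens) for inhibition, read by MTT assay (on this read-out lower numbers stand for stronger inhibition of growth and higher numbers for weaker inhibition of growth), compound 1, `CC1=C(/C=C/C(C)=C/C=C/C(C)=C\C(=O)Nc2ccccc2)C(C)(C)CC=C1c1cccnc1`, gives 8320 nM. Compound 2, `CC1=C(/C=C/C(C)=C/C=C/C(C)=C\C(=O)NCc2ccc(O)cc2)C(C)(C)CCC1n1ccnc1`, gives 160 nM in this assay, the lowest of the two numbers; compound 1 sits far enough above it that the gap lies beyond the usual scatter. The two compounds differ in several places at once, so nothing more than their two numbers can be read from them.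

Compound 3, `CC1=C(/C=C/C(C)=C/C=C/C(C)=C\C(=O)Nc2ccccc2O)C(C)(C)CCC1n1ccnc1`, differs from compound 2 in a single place: 2-hydroxyphenyl in place of 4-hydroxybenzyl on an amide-type nitrogen. Going by the values given here, no measured pair that differs only in this way is available, so the size of the step rests on judgment. A moderate weakening is expected, a step of a 3.1-fold higher number from compound 2 to compound 3 (0.49 log units; beyond the scatter) in this assay, since compound 1, also carrying its ring directly on the amide nitrogen, gives 8320 nM. Compound 3 is therefore estimated at 500 nM, with a range from 150 nM to 2500 nM.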

Compound 3, concentration for 50% growth inhibition: 1090 nM
Beside the measured number, compound 3's estimate is 2.2-fold (0.34 log units) below it, and the stated range covers the measured number.
By their numbers in this assay, from the lowest: compound 2; then compound 3; then compound 1.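

In this assay, replacing 4-hydroxybenzyl with 2-hydroxyphenyl on the amide-type nitrogen gives a 6.8-fold higher number from compound 2 to compound 3 (0.83 log units; beyond the scatter) and so weaker inhibition of growth. Going by these compounds alone, this is the first comparison in which only this group changes, and it shows that the group on this nitrogen matters, even though both groups carry one six-membered aromatic ring of carbon only and the same counts of hydrogen-bond donors and acceptors. Nothing measured here explains the size of this step.

As far as these compounds go, the swap changes two things at once: the carbon link to the ring is lost and the hydroxyl sits at a different ring position, so their separate contributions remain unknown. A 4-hydroxyphenyl or 2-hydroxybenzyl group would separate the two, while a group such as a carboxylic acid on the ring would test another kind of substituent.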